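A few compounds are considered here, and "the series" means these few. Any claim that something is new, unique, unknown or untested is made for them only; others in the source may bear on it.

Measured so far in a functional assay on MCF7 cells (Homo sapiens) for antiproliferative activity, read by sulforhodamine B assay, with a stated time of 48 h; a lower number here means a stronger inhibitor, a higher number a weaker inhibitor:

Compound 1 `O=C1NCCN1c1ccc(S(=O)(=O)Nc2cccc(Br)c2)cc1` gives 100 nM
Compound 2 `Cc1cccc(NS(=O)(=O)c2ccc(N3CCNC3=O)cc2)c1C` gives 230 nM

Compound 2 holds the higher of these two numbers, which makes it the weaker inhibitor of the pair. It differs from compound 1 in one place, with 2,3-dimethylphenyl in place of 3-bromophenyl on a sulfonamide nitrogen.

Compound 3 `Cc1ccc(C)c(NS(=O)(=O)c2ccc(N3CCNC3=O)cc2)c1` has not yet been measured. It has the same atoms as compound 2, joined differently (2,5-dimethylphenyl in place of 2,3-dimethylphenyl on a sulfonamide nitrogen), with 2,5-dimethylphenyl in place of 2,3-dimethylphenyl on a sulfonamide nitrogen. For the measured compounds named here, no measured pair tests a rearrangement of this kind. Going by the values given here, the one step that bears on it is a 2.3-fold higher number from compound 1 to compound 2 (0.36 log units; beyond the scatter) at the same nitrogen, a modest change that swapped one group for a different set of atoms, whereas here the atoms stay the same. That modest size is therefore a rough upper guide, and the data favour no direction. In this assay the expected change is a 1.1-fold lower number from compound 2 to compound 3 (0.04 log units; within the scatter) and nothing beyond the scatter is expected. For compound 3 the estimated value is 210 nM within an expected range (90 nM to 500 nM).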

Compound 3, half-maximal inhibitory concentration: 48 nM
Estimate against measurement, compound 3: 4.4-fold (0.64 log units) above, and the stated range ends above it.
By their numbers in this assay, from the lowest: compound 3; then compound 1; then compound 2.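

In this assay, rearranging the same atoms on the ring carried by the sulfonamide nitrogen gives a 4.8-fold lower number from compound 2 to compound 3 (0.68 log units; beyond the scatter) when 2,5-dimethylphenyl takes the place of 2,3-dimethylphenyl. At this position, then, the activity depends not only on which atoms the group contains but also on how they are arranged, a point that the earlier swap between two different groups could not separate. The rearranged group also improves on the 3-bromophenyl group, with a 2.1-fold lower number from compound 1 to compound 3 (0.32 log units; beyond the scatter) in the same assay, making compound 3 the strongest inhibitor of the three, but no measurement here explains why the arrangement matters or why this one does best.

The compounds shown cover only two placements of the two methyl groups and one bromine-bearing ring, so it remains open whether 3,5-dimethylphenyl or a ring with a single methyl group would do as well. On these data alone, it is also open whether the advantage of the arrangement in 2,5-dimethylphenyl would survive with other groups on the ring, such as two chlorine atoms, two methoxy groups or an amine.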